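This account rests on a few compounds, and the source may have more. Where it says the series, first, only, none or still open, it means among the compounds named here.

Measured compounds:
compound 1 `CCCCNC(=O)C1C(C(=O)O)[C@@H]2CC[C@H]1O2`, 10000 nM
compound 2 `CCc1ccccc1NC(=O)C1C(C(=O)O)[C@@H]2CC[C@H]1O2`, 10000 nM
compound 3 `C/C(=N/Nc1ccccc1)c1ccccc1NC(=O)C1C(C(=O)O)[C@@H]2CC[C@H]1O2`, 10000 nM

All three share one core and differ only in the group on the amide nitrogen. In an ADME assay on BE(2)-C cells (Homo sapiens) for cytotoxicity, read by MTT assay, with a stated time of 72 h (a lower number here means a stronger inhibitor of growth, a higher number a weaker inhibitor of growth), compound 1 gives 10000 nM, compound 2 gives 10000 nM and compound 3 gives 10000 nM, so compound 1 stands level with both at the digits shown, and none of the three can be told apart within the scatter.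

Compound 4 `O=C(O)CCCNC(=O)C1C(C(=O)O)[C@@H]2CC[C@H]1O2` has not been measured. The change from compound 1 is carboxy in place of methyl on a saturated chain carbon, three bonds along the chain from an amide-type nitrogen. Among the measured compounds shown here, nothing among the measured compounds shows a shift with any amide substituent, so no step beyond the scatter is expected. Compound 4 is therefore estimated at 10000 nM, between 5000 nM and 20000 nM, a step of no change at the digits printed from compound 1 to compound 4 (within the scatter) expected.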

Compound 4, concentration for 50% growth inhibition: 10000 nM
Compound 4: middle estimate and measured number agree at the digits printed; measured number inside the range.
By their numbers in this assay, from the lowest: compounds 1, 2, 3 and 4 (each within the scatter of the next).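

In this assay, carboxy in place of methyl on a saturated chain carbon, three bonds along the chain from an amide-type nitrogen, gives no change at the digits printed from compound 1 to compound 4 (within the scatter) and so leaves the read-out unmoved. Among the compounds shown here, the earlier compounds varied the amide substituent but carried no carboxy on this chain, so this is the first sign that this swap does not separate compounds here. No measurement is available that would explain this result.

On these data alone, an amine on the same chain carbon remains open, as does a longer chain ending in a carboxylic acid. Also open, as far as these compounds go, is whether any amide substituent can move the number in this assay.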